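The compounds below may be only part of what the source reports. "The series", "measured", "known", "first", "only" and "open" are said of these compounds alone.

Values in a functional assay, read by fluorescence and spectrophotometry, with a stated time of 1 h (a higher number here means that more compound is needed for the effect, a lower number that less compound is needed), so far
compound 1 `C=CCCCCCCCS(=O)(=O)/C=C/c1ccc(O)c(O)c1` with 6900 nM measured
compound 2 `O=S(=O)(/C=C/c1ccc(O)c(O)c1)CCCCCCCCO` with 6700 nM measured
compound 3 `CCCCCS(=O)(=O)/C=C/c1ccc(O)c(O)c1` not yet measured

Going by the values given here, the only measured step is a 1.0-fold lower number from compound 1 to compound 2 (0.01 log units; within the scatter) and it leaves compound 2 level with compound 1, so neither stands apart on these numbers.

The move from compound 2 to compound 3 is hydrogen in place of 3-hydroxypropyl (hydrogen in place of 3-hydroxypropyl on a saturated chain carbon, five bonds along the chain from a sulfonyl sulfur) on a saturated chain carbon. The same difference, cut one bond further out, reads 6-hydroxyhexyl to propyl.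

Among the compounds with values here, the one measured step bears on this only in part. Within the data shown here, it exchanged the end of the chain, hydroxymethyl in place of vinyl, and no measured pair shows what removing 3-hydroxypropyl does. The working expectation therefore starts from compound 2 at 6700 nM and stays cautious, with no direction favoured in this assay and a wide range kept open. The estimated change is a 1.0-fold higher number from compound 2 to compound 3 (0.02 log units; within the scatter) and so no step beyond the scatter is expected. For compound 3 the estimated value is 7000 nM with an expected range from 2500 nM to 20000 nM on present data.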

Compound 3, half-maximal effective concentration: 8100 nM
Compound 3: middle estimate off by 1.2-fold (0.06 log units), on the low side; the measured number falls inside the stated range.
By their numbers in this assay, from the lowest: compounds 2, 1 and 3 (each within the scatter of the next).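

In this assay, cutting the chain at the saturated carbon five bonds along from the sulfonyl sulfur removes 3-hydroxypropyl, with its 4 heavy atoms and its hydrogen-bond donor and acceptor, and the result is a 1.2-fold higher number from compound 2 to compound 3 (0.08 log units; within the scatter). The same cut, with but-3-en-1-yl leaving in place of 3-hydroxypropyl, gives a 1.2-fold higher number from compound 1 to compound 3 (0.07 log units; within the scatter). Earlier, only the end of the chain had been exchanged; these two steps add that, among these three compounds, the outer part of the chain can go altogether, whichever of the two ends it carries, without a step beyond the scatter, and no information on the cause of this is available.

Going by these compounds alone, with all three compounds within the scatter of one another, the series so far shows no group at this position that moves the number, so it remains unclear whether this position can influence the read-out at all. A chain end carrying an amine or a carboxylic acid, or a longer chain, could test this, and each remains an open case for the shared core.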